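Aniline substituent change on a pyridinylpyrimidine anilino series

A few compounds are considered here, and "the series" means these few. Any claim that something is new, unique, unknown or untested is made for them only; others in the source may bear on it.

Measured compounds:
compound 1 `Nc1cccc(Nc2nccc(-c3ccccn3)n2)c1` gives 300 nM in a functional assay for inhibition, with Homo sapiens as the target; a lower number here means a stronger inhibitor, a higher number a weaker inhibitor
compound 2 `Cc1cccc(Nc2nccc(-c3ccc(C)o3)n2)c1` gives 2000 nM in this assay
compound 3 `Cc1cccc(Nc2nccc(-c3ccncc3)n2)c1` gives 8800 nM in this assay

Compound 1 stands lowest of the three numbers; compound 2 is nearest and compound 3 furthest, both beyond the scatter. Within the data shown here, the only single-place step, a 4.4-fold higher number from compound 2 to compound 3 (0.64 log units; beyond the scatter), concerns the group on the core, not the anilino substituent, so it does not bear on the change to compound 4 `CCOC(=O)c1cccc(Nc2nccc(-c3ccccn3)n2)c1`: ethoxycarbonyl in place of amino on an aromatic carbon, on an aromatic carbon, meta to a large group. Among the measured compounds shown here, no measured pair isolates this substituent. A weakening is expected, of moderate size, a 2.3-fold higher number from compound 1 to compound 4 (0.37 log units; beyond the scatter). Compound 4 is estimated at 700 nM, range 150 nM to 3500 nM.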

Compound 4, half-maximal inhibitory concentration: 3000 nM
For compound 4 the middle estimate is 4.3-fold (0.63 log units) below the measured one; the range from low to high includes it.
By their numbers in this assay, from the lowest: compound 1; then compounds 2 and 4 (each within the scatter of the next); then compound 3.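

In this assay, ethoxycarbonyl in place of amino on an aromatic carbon, meta to a large group, gives a 10-fold higher number from compound 1 to compound 4 (1.00 log units; beyond the scatter). This is the first step shown at this position with the rest of compound 1 held fixed, and it shows that the number responds to the group placed there. Nothing measured on hand accounts for the size of this step.

Going by these compounds, whether a carboxylic acid or a primary amide at this position would stay closer to compound 1 remains open. So does whether a shorter ester would behave like ethoxycarbonyl.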